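Swapping a pyrimidine for a chlorothiophene on the amine

The compounds below may be only part of what the source reports. "The series", "measured", "known", "first", "only" and "open" are said of these compounds alone.

Compound 2 `C[C@H]1[C@H](NCc2cncnc2)C[C@H]2C[C@@H]1C2(C)C` was tested in an ADME assay on MDCK cells (Canis lupus familiaris) for cytotoxicity, read by microscopy, with a stated time of 48 h; on this read-out lower numbers stand for higher toxicity in this test and higher numbers for lower toxicity in this test. In this assay compound 2 reaches only the assay's limit, > 100000 nM, so no exact number is known for it. Compound 3 `C[C@H]1[C@H](NCc2ccc(Cl)s2)C[C@H]2C[C@@H]1C2(C)C` differs from compound 2 in one place: 5-chlorothiophen-2-yl in place of pyrimidin-5-yl on a saturated chain carbon bound to an amine nitrogen. The nearest measured step runs the opposite way: an at least 2.3-fold higher number from compound 1 to compound 2 (0.36 log units; beyond the scatter), where compound 1 `C[C@H]1[C@H](NCc2ccc(Br)s2)C[C@H]2C[C@@H]1C2(C)C` gives 43000 nM in this assay; that step is itself bounded by the limit of > 100000 nM in this assay, at which 1 of the 2 values shown sits. Reversing it, compound 3 is expected to give 45000 nM, within 20000 nM to 100000 nM. The expected step is an at least 2.2-fold lower number from compound 2 to compound 3 (0.34 log units; beyond the scatter).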

Compound 3, minimum cytotoxic concentration: 25000 nM
Compound 3: the middle estimate sits 1.8-fold (0.26 log units) above what was measured; the range from low to high includes it.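

In this assay, putting 5-chlorothiophen-2-yl in place of pyrimidin-5-yl gives an at least 4.0-fold lower number from compound 2 to compound 3 (0.60 log units; beyond the scatter). Exchanging bromo for chloro on the thiophene gives a 1.7-fold lower number from compound 1 to compound 3 (0.24 log units; within the scatter), so these two halogens cannot be told apart here, and both halogenated thiophenes give lower numbers than the pyrimidine. The true size of the pyrimidine step remains unknown, since compound 2 stands at a limit: the limit of > 100000 nM in this assay, at which 1 of the 3 values shown sits.

The compounds shown leave open whether the thiophene ring or its halogen accounts for the lower numbers. A plain thiophen-2-yl group on the same carbon would separate the two.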